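The source may hold more compounds than are shown below. What is called first, only, known or untested is meant among the compounds shown, and "the series" means these compounds.

Going by the values given here, compound 2, `CCCN(CCC#N)c1nc(C)nc(N(CC)c2ccc(N(C)C)cc2C)n1`, gives 7 nM in an assay on isolated protein for binding affinity to corticotropin-releasing factor receptor 1 (Homo sapiens) (a higher number here means a weaker inhibitor, a lower number a stronger inhibitor), the lowest of the two numbers so far; compound 1, `CCN(CC)c1cc(C)nc(N(CC)c2c(Br)cc(OC)cc2OC)n1`, gives 48 nM in this assay, a higher figure that lies beyond the scatter. Compound 3, `CCCCN(CCC#N)c1nc(C)nc(N(CC)c2ccc(N(C)C)cc2C)n1`, differs from compound 2 by methyl in place of hydrogen on a saturated chain carbon, three bonds along the chain from a nitrogen on an aromatic ring, that is, propyl to butyl. Among the compounds with values here, no pair of measured compounds shares this change, so there is nothing to set the step against. A single extension of a chain is expected to move the number little, so the step from compound 2 to compound 3 is expected to be a 1.1-fold higher number from compound 2 to compound 3 (0.06 log units; within the scatter), not beyond the scatter. Compound 3 is therefore estimated at 8 nM, within 3 nM to 25 nM.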

Compound 3, inhibition constant: 8 nM
For compound 3 middle estimate and measured number coincide at the digits printed, within the range that was stated.
By their numbers in this assay, from the lowest: compounds 2 and 3 (each within the scatter of the next); then compound 1.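

In this assay the change from propyl to butyl on this chain gives a 1.1-fold higher number from compound 2 to compound 3 (0.06 log units; within the scatter), so at this position the added methyl does not move the number beyond the scatter. Going by these compounds alone, this is the first comparison between compounds that differ in one place, which compound 1 could not provide. Nothing available accounts for this result. A single step leaves open how far this tolerance reaches. A shorter ethyl chain, a longer hexyl chain, or an amine or carboxylic acid at the chain end could each give a different number.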